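This account rests on a few compounds, and the source may have more. Where it says the series, first, only, none or still open, it means among the compounds named here.

Measured so far in a functional assay on U-87MG ATCC cells for antiproliferative activity against U-87 MG (Homo sapiens), read by MTT assay, with a stated time of 72 h; on this read-out lower numbers stand for stronger inhibition and higher numbers for weaker inhibition:
- compound 1 `Cc1nn(C)c(Oc2cccc(F)c2)c1/C=N\CCCCCOc1cc2oc(=O)cc(C)c2cc1Cl`: 9870 nM
- compound 2 `Cc1nn(C)c(Oc2cccc(F)c2F)c1/C=N\CCCCCCOc1cc2oc(=O)cc(C)c2cc1Cl`: > 25000 nM

Compound 2 stands at the limit of > 25000 nM in this assay, at which 1 of the 2 values shown sits; its value is a limit of the assay, not a number. Compound 3 `Cc1nn(C)c(Oc2ccccc2Br)c1/C=N\CCCCCCOc1cc2oc(=O)cc(C)c2cc1Cl` arises from compound 2 by 2-bromophenyl in place of 2,3-difluorophenyl on an oxygen on an aromatic ring. Going by the values given here, no step between two measured compounds is known here, so the direction of the change is open. The expected step of an at least 1.5-fold lower number from compound 2 to compound 3 (0.19 log units; that floor lies within the scatter) is small, within the usual scatter. Compound 3 is estimated at 16000 nM, with a range from 4000 nM to 40000 nM.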

Compound 3, half-maximal inhibitory concentration: 21800 nM
Compound 3: the middle estimate sits 1.4-fold (0.13 log units) below what was measured, within the range that was stated.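

Compound 2 carries only a limit in this assay, not a number: the limit of > 25000 nM in this assay, at which 1 of the 3 values shown sits. On an oxygen on an aromatic ring, 2-bromophenyl in place of 2,3-difluorophenyl gives an at least 1.1-fold lower number from compound 2 to compound 3 (0.05 log units; that floor lies within the scatter), so this change yields a measurable value, but its true size stays unresolved. Compound 1 differs from both compounds in more than one place, so steps to it cannot be read.

Still open, from the compounds shown here alone, is whether an amine or a carboxylic acid on this aromatic ring would move the number beyond the scatter. Going by these compounds, the effect of a longer chain also remains open.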